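Series notes: homologating the acid of compound 3

The compounds below may be only part of what the source reports. "The series", "measured", "known", "first", "only" and "open" are said of these compounds alone.

All three measured compounds were run in an assay on cells (Hepatocyte, strain Sprague-Dawley) for inhibition of acyl-CoA desaturase 1 (Rattus norvegicus), read by HPLC; on this read-out lower numbers stand for stronger inhibition and higher numbers for weaker inhibition. Compound 1 `O=C(O)c1cncc(-c2ccc(N3CCC(Oc4ccccc4C(F)(F)F)CC3)nn2)c1` gives 1300 nM. Compound 2 `O=C(O)c1cncc(-c2ccc(N3CCC(Oc4ccccc4Br)CC3)nn2)c1` gives 1640 nM. Compound 3 `O=C(O)c1cncc(-c2ccc(N3CCC(Oc4cc(F)ccc4Br)CC3)nn2)c1` gives 175 nM.

Compound 3 carries the lowest number of the three: a 7.4-fold lower number from compound 1 to compound 3 (0.87 log units; beyond the scatter), and a 9.4-fold lower number from compound 2 to compound 3 (0.97 log units; beyond the scatter). The two halogen variants sit together, since a 1.3-fold higher number from compound 1 to compound 2 (0.10 log units; within the scatter). So far the only change that moved the read-out beyond the scatter is the fluoro added to the aryloxy ring, and the single-atom swaps on that ring otherwise did little.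

Compound 4 `O=C(O)Cc1cncc(-c2ccc(N3CCC(Oc4cc(F)ccc4Br)CC3)nn2)c1` keeps the whole of compound 3 apart from one change: carboxymethyl in place of carboxy on an aromatic carbon. Among the compounds with values here, none of the measured steps bears on this position; all three concern the aryloxy ring, so there is no measured precedent here for inserting one carbon between the pyridine and the acid. Such homologations are often tolerated but rarely free, so a modest rise in the number is expected, with wide uncertainty: a 2.6-fold higher number from compound 3 to compound 4 (0.41 log units; beyond the scatter) is the expected step. For compound 4 in this assay the estimate is 450 nM, with a range of 130 nM to 1600 nM.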

Compound 4, half-maximal inhibitory concentration: 75 nM
Compound 4: the middle estimate sits 6.0-fold (0.78 log units) above what was measured, and the stated range ends above it.
By their numbers in this assay, from the lowest: compound 4; then compound 3; then compounds 1 and 2 (each within the scatter of the next).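

In this assay, this position proves to be a live one: carboxymethyl in place of carboxy on an aromatic carbon gives a 2.3-fold lower number from compound 3 to compound 4 (0.37 log units; beyond the scatter), so the extra carbon is not merely tolerated but moves the number down by a step beyond the scatter. Every earlier step concerned the aryloxy ring, which makes this the first change away from that ring to shift the read-out, and it shows that the part of the molecule carrying the acid also bears on inhibition in this series. Nothing available here bears on why the added carbon lowers the number.

The compounds shown leave open whether the trend runs further, since a single carbon added is one point and a longer chain carrying the carboxylic acid, or an amide in place of that acid, could go either way. They also leave open whether carboxymethyl gives a similar step with the other aryloxy rings of the series, such as the 2-(trifluoromethyl)phenyl group of compound 1, as the change has been read only on the aryloxy ring of compound 3.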